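From Compound 3 to Compound 4: Awaiting a Read-out

The source may hold more compounds than are shown below. What is called first, only, known or untested is meant among the compounds shown, and "the series" means these compounds.

Compound 1 `COc1cc(Cl)cc(-c2nn(-c3cccc(NC(=O)Nc4ccc(Cl)c(C(F)(F)F)c4)c3)cc2-c2ccncc2)c1`, compound 2 `COc1cc(Cl)cc(-c2nn(-c3cccc(NC(=O)Nc4ccc(Cl)c(Cl)c4)c3)cc2-c2ccncc2)c1` and compound 3 `COc1cc(Cl)cc(-c2nn(-c3cccc(NC(=O)Nc4cccc(C(F)(F)F)c4)c3)cc2-c2ccncc2)c1` share one core and differ only in the aryl group on the amide-type nitrogen. In a functional assay on CCRF-CEM cells (Homo sapiens) for inhibition, read by sulforhodamine B assay, with a stated time of 48 h, tested at 0.1 uM (a higher number here means a weaker effect of the compound at the concentration tested, a lower number a stronger effect), compound 1 gives 97%, compound 2 gives 97%, and compound 3 gives 97%. The steps of no change at the digits printed from compound 1 to compound 2 (within the scatter), no change at the digits printed from compound 1 to compound 3 (within the scatter) and no change at the digits printed from compound 2 to compound 3 (within the scatter) all lie within the scatter, so compound 3 stands level with compounds 1 and 2. Compound 4 `COc1cc(Cl)cc(-c2nn(-c3cccc(NC(=O)c4cccc(C(F)(F)F)c4)c3)cc2-c2ccncc2)c1` differs from compound 3 by 3-(trifluoromethyl)phenyl in place of (3-(trifluoromethyl)phenyl)amino on a carbonyl carbon. Among the compounds with values here, no measured step touches that carbonyl carbon; the three known steps change only the aryl group and show nothing beyond the scatter. With compound 3 already near the top of the scale, the expected step of a number 3 percentage points lower from compound 3 to compound 4 (within the scatter) is small, with a little room downward. Compound 4 is therefore estimated at 94%, between 78% and 104%.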

Compound 4, a percentage reported as activity, at one concentration (the size of the read-out at that concentration, not a potency): 92%
The estimate for compound 4 lay 2 percentage points above the measured number; the range from low to high includes it.
By their numbers in this assay, from the lowest: compounds 4, 1, 2 and 3 (each within the scatter of the next).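

Within the data shown here, this is the first change at the carbonyl carbon itself, and in this assay the (3-(trifluoromethyl)phenyl)amino group gives way to 3-(trifluoromethyl)phenyl with its nitrogen gone (a number 5 percentage points lower from compound 3 to compound 4 (within the scatter)). The comparisons with the other two compounds read the same (a number 5 percentage points lower from compound 2 to compound 4 (within the scatter); a number 5 percentage points lower from compound 1 to compound 4 (within the scatter)), so this position tolerates losing that nitrogen without leaving the scatter. Nothing at hand bears on why. Still open, from the compounds shown here alone, is whether a methylene or an ether oxygen at this place, or an amine or a carboxylic acid on the aryl ring, would move the number beyond the scatter.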